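Replacing iodo with ethoxy: notes on compound 4

The source may hold more compounds than are shown below. What is called first, only, known or untested is meant among the compounds shown, and "the series" means these compounds.

- compound 1 `COc1ccccc1Sc1c[nH]c2ccc(Cl)cc12`: > 2500 nM (a limit of the assay, not a number)
- compound 2 `Cc1cc(C)cc(Sc2c[nH]c3ccc(Cl)cc23)c1`: 1200 nM
- compound 3 `COc1cc(Sc2c[nH]c3ccc(I)cc23)cc(OC)c1OC`: 68 nM

All three values come from a functional assay on MCF7 cells (Homo sapiens) for inhibition, with a stated time of 48 h; a lower number here means a stronger inhibitor, a higher number a weaker inhibitor. Compound 1 gives only a limit, > 2500 nM, and no number. Of the two actual numbers, compound 3 has the lower at 68 nM. The nearest is compound 2 at 1200 nM, a gap well beyond the scatter.

The next compound is compound 4 `CCOc1ccc2[nH]cc(Sc3cc(OC)c(OC)c(OC)c3)c2c1`, which carries ethoxy in place of the iodo of compound 3 (ethoxy in place of iodo on an aromatic carbon). The change sits on an aromatic carbon of a six-membered aromatic ring of carbon only, part of a fused or bridged system of two rings.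

Among the measured compounds shown here, no measured pair isolates this change, so any expectation for it is weakly grounded. A modest move toward a higher number in this assay is expected, of a size near the scatter or somewhat beyond it. For the measured compounds named here, compound 3 at 68 nM is the lowest number so far, which leaves more room for a rise than for a fall. The expected size of the change is a 2.2-fold higher number from compound 3 to compound 4 (0.34 log units; beyond the scatter). For compound 4 the estimated value is 150 nM, with an expected range of 35 nM to 700 nM.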

Compound 4, half-maximal inhibitory concentration: 16 nM
Beside the measured number, compound 4's estimate is 9.4-fold (0.97 log units) above it, and the stated range ends above it.
By their numbers in this assay, from the lowest: compound 4; then compound 3; then compound 2. At a limit, above all of these: compound 1.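

On this aromatic carbon of the shared core, iodo is not needed for a low number in this assay: ethoxy in place of iodo gives a 4.3-fold lower number from compound 3 to compound 4 (0.63 log units; beyond the scatter). Among the compounds shown here, this is the only step that isolates a single place, and it shows that the position responds to its group and accepts ethoxy, with 3 heavy atoms and 1 hydrogen-bond acceptor, where iodo had 1 heavy atom and no acceptor. Nothing shown here accounts for the direction or size of the step.

As far as these compounds go, with one step at this position, it remains open whether the lower number is particular to ethoxy or extends to a longer chain such as propoxy, to a small alkyl group such as methyl, or to an amine or a carboxylic acid on the same carbon. From the compounds shown here alone, it also remains open whether the same exchange would give a step of similar size with a different aryl group on the sulfur, since compound 3 and compound 4 share one aryl group and so test the change in that setting alone.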